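The source may hold more compounds than are shown below. What is called first, only, known or untested is meant among the compounds shown, and "the series" means these compounds.

Compound 1 `CCOC(=O)c1c(C)coc1-c1ccc2c(CC)cccc2c1OC` carries an ethyl ester on a carbonyl carbon of its shared core. In a functional assay on KBVIN cells (Homo sapiens) for cytotoxicity, read by MTT assay, with a stated time of 72 h (a higher number here means that more compound is needed for the effect, a lower number that less compound is needed), compound 1 gives 1.8 ug/mL. Compound 2 `CCc1cccc2c(OC)c(-c3occ(C)c3C(=O)NC)ccc12` is the same core with a methylamino group in place of the ethoxy group on that carbonyl carbon. In this assay compound 2 gives > 10 ug/mL, which is a limit of the assay and not a number; the evidence shows (the limit of > 10 ug/mL in this assay, at which 1 of the 2 values shown sits). Among the measured compounds shown here, the only measured step is an at least 5.5-fold higher number from compound 1 to compound 2 (0.74 log units; beyond the scatter), and it says that replacing the ester oxygen by an amide nitrogen costs activity. Compound 3 `CCc1cccc2c(OC)c(-c3occ(C)c3C(=O)On3nnc4ccccc43)ccc12` differs from compound 2 by a group of 10 heavy atoms (6 carbon, 3 nitrogen, 1 oxygen; one five-membered aromatic ring with 3 hetero atoms, one six-membered aromatic ring of carbon only) in place of a group of 2 heavy atoms (1 carbon, 1 nitrogen; no ring), on a carbonyl carbon, so it returns to an ester-type link, now to a larger aromatic group. Given that the ester compound 1 gives 1.8 ug/mL, compound 3 is expected to move back toward lower numbers, with the step of an at least 3.3-fold lower number from compound 2 to compound 3 (0.52 log units; beyond the scatter) estimated to be appreciable. Compound 3 is therefore estimated at 3 ug/mL, within a range from 0.8 ug/mL to 12 ug/mL.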

Compound 3, concentration for half-maximal effect: > 10 ug/mL
Compound 3 ended at the assay's limit; the forecaster's own chance of this, stated with the estimate: 25%; middle value at least 3.3-fold (0.52 log units) from the limit.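

Returning to an ester-type link on the carbonyl carbon does not by itself restore activity: this assay shows an at least 5.5-fold higher number from compound 1 to compound 3 (0.74 log units; beyond the scatter), so the group attached to the oxygen matters, not only the presence of that oxygen. In this assay compound 3 gives > 10 ug/mL, which is a limit of the assay and not a number, so the step from compound 2 to compound 3 cannot be read. Of the three groups on this carbonyl carbon, only the ethoxy group of compound 1 gives a readable value, and the other two end at the same limit: the limit of > 10 ug/mL in this assay, at which 2 of the 3 values shown sit.

From the compounds shown here alone, it remains open whether a methyl group or a longer chain such as butyl on that oxygen would also give a readable value. Going by these compounds, what a carboxylic acid at this carbonyl carbon would give also remains open.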